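Methoxy for Chloro: What to Expect for Compound 4

The compounds below may be only part of what the source reports. "The series", "measured", "known", "first", "only" and "open" are said of these compounds alone.

Of the compounds shown here, three sharing one core have been measured in a functional assay on A549 cells (Homo sapiens) for antiproliferative activity, read by MTT assay, with a stated time of 48 h; a higher number here means a weaker inhibitor, a lower number a stronger inhibitor. Compound 1 `COc1ccc(-c2nnc(NC(=O)/C=C/c3ccccc3)s2)cc1` gives 0.68 ug/mL, compound 2 `O=C(/C=C/c1ccccc1)Nc1nnc(-c2ccc(Cl)cc2)s1` gives 2.02 ug/mL, and compound 3 `Cc1ccc(/C=C/C(=O)Nc2nnc(-c3ccc(Cl)cc3)s2)cc1` gives 1.25 ug/mL. Compound 3 stands second highest of the three numbers, yet its value lies within the scatter of both compound 2 and compound 1, so no order among the three can be claimed from these pairs alone. Two single-point steps connect the set: a 3.0-fold higher number from compound 1 to compound 2 (0.47 log units; beyond the scatter), and a 1.6-fold lower number from compound 2 to compound 3 (0.21 log units; within the scatter).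

Compound 4 `COc1ccc(-c2nnc(NC(=O)/C=C/c3ccc(C)cc3)s2)cc1` has not yet been measured. It differs from compound 3 by methoxy in place of chloro on an aromatic carbon. Within the data shown here, one measured step bears directly on this change, being the same exchange run in the opposite direction: a 3.0-fold higher number from compound 1 to compound 2 (0.47 log units; beyond the scatter). The other step, the methyl in place of hydrogen, stayed within the scatter and does not speak to the present change. Reversing the one relevant step, a modest move to a lower number is expected for compound 4, roughly a 2.8-fold lower number from compound 3 to compound 4 (0.44 log units; beyond the scatter). Compound 4 is therefore estimated at 0.45 ug/mL, with a likely range from 0.2 ug/mL to 1 ug/mL.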

Compound 4, half-maximal inhibitory concentration: 0.58 ug/mL
Compound 4: the middle estimate sits 1.3-fold (0.11 log units) below what was measured; the range from low to high includes it.
By their numbers in this assay, from the lowest: compounds 4, 1, 3 and 2 (each within the scatter of the next, the first and the last beyond it).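

With a 2.2-fold lower number from compound 3 to compound 4 (0.33 log units; beyond the scatter) in this assay, the exchange of chloro for methoxy now has a second reading, on the core that carries the methyl, and the two readings agree in direction and within the scatter in size: the same change on two cores in this assay, a 3.0-fold higher number (0.47 log units; beyond the scatter) from compound 1 to compound 2 and a 2.2-fold higher number (0.33 log units; beyond the scatter) from compound 4 to compound 3, 1.4-fold (0.14 log units) apart, within the scatter of two such steps The methyl has now also been read on both cores, and with a 1.2-fold lower number from compound 1 to compound 4 (0.07 log units; within the scatter) it stays within the scatter on each: the same change on two cores in this assay, a 1.6-fold lower number (0.21 log units; within the scatter) from compound 2 to compound 3 and a 1.2-fold lower number (0.07 log units; within the scatter) from compound 1 to compound 4, 1.4-fold (0.14 log units) apart, within the scatter of two such steps Across these four compounds, the only steps beyond the scatter are those at the aromatic carbon para to a large group, where going from 4-chlorophenyl to 4-methoxyphenyl gives the lower number both times, and no step shown goes against this.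

The compounds shown hold only chloro and methoxy at this position, so they cannot tell whether a hydroxyl, an ethyl or an amine there would fall with methoxy or with chloro. They also leave open whether the ring carrying the methyl would stay as flat in its response with a nitro group or a carboxylic acid in the methyl's place.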